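Returning a Basic-Looking Chain to the Aryl Nitrogen

The source may report more compounds than this note shows. Statements on the series, on what has been measured and on what is new or still open speak of the compounds shown alone.

Three compounds share one core and differ only in the group on an aromatic carbon. Compound 1 `CN(C)CCN(CCN(C)C)c1ccc(C(=O)N2CCc3ccc(OS(N)(=O)=O)cc3C2)cc1` gives 15.9% in an assay on HEK293 cells for inhibition of Steryl-sulfatase (Homo sapiens), tested at 1 uM; on this read-out higher numbers stand for a stronger effect at the one concentration tested and lower numbers for a weaker effect. Compound 2 `CC(C)CCN(CCC(C)C)c1ccc(C(=O)N2CCc3ccc(OS(N)(=O)=O)cc3C2)cc1` gives 90.8%, and compound 3 `CCN(Cc1ccccc1)c1ccc(C(=O)N2CCc3ccc(OS(N)(=O)=O)cc3C2)cc1` gives 83.6%. Compound 3 therefore stands second highest of the three numbers: its nearest neighbour is compound 2, with a number 7.2 percentage points lower from compound 2 to compound 3 (within the scatter), and its furthest is compound 1, with a number 67.7 percentage points higher from compound 1 to compound 3 (beyond the scatter).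

Compound 4 `CN(CCN1CCCCC1)c1ccc(C(=O)N2CCc3ccc(OS(N)(=O)=O)cc3C2)cc1` is the next compound, not yet measured. Among the compounds with values here, its single difference from compound 3 is methyl(2-(piperidin-1-yl)ethyl)amino in place of benzyl(ethyl)amino on an aromatic carbon.

Within the data shown here, two measured steps bear on this. Both replacements of bis(2-(dimethylamino)ethyl)amino gave large rises, a number 74.9 percentage points higher from compound 1 to compound 2 (beyond the scatter) and a number 67.7 percentage points higher from compound 1 to compound 3 (beyond the scatter). Compound 4 carries methyl(2-(piperidin-1-yl)ethyl)amino, which shares with compound 1 a chain ending in a second nitrogen, while compound 3 has none. A fall in this assay is therefore expected, likely beyond the scatter but smaller than the whole distance back to compound 1, since only one such chain enters. The expected step is a number 38.6 percentage points lower from compound 3 to compound 4 (beyond the scatter). For compound 4 the estimate in this assay is 45%, within a range from 15% to 78%.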

Compound 4, a percentage reported as inhibition, at one concentration (the size of the read-out at that concentration, not a potency): 26.8%
The estimate for compound 4 lay 18.2 percentage points above the measured number; the range from low to high includes it.
By their numbers in this assay, from the lowest: compound 1; then compound 4; then compounds 3 and 2 (each within the scatter of the next).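

In this assay the swap of benzyl(ethyl)amino for methyl(2-(piperidin-1-yl)ethyl)amino leaves the count at 10 heavy atoms, yet it gives a number 56.8 percentage points lower from compound 3 to compound 4 (beyond the scatter) as the result, so the heavy-atom count of this group does not by itself set the read-out. The same loss shows against the diisopentylamino group, with a number 64 percentage points lower from compound 2 to compound 4 (beyond the scatter) as the step, which means that the earlier high numbers do not carry over to every amino group at this aromatic carbon. Until now only compound 1, with two chains ending in a further nitrogen, had given a low number, but one such chain already takes the read-out most of the way down, leaving a number 10.9 percentage points higher from compound 1 to compound 4 (beyond the scatter) as the remaining gap.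

Nothing measured here explains the fall. As far as these compounds go, whether it follows the second nitrogen or simply the ring-bearing ethyl chain stays open, and a methyl(2-cyclohexylethyl)amino group, which has carbon where the piperidine has its nitrogen, would separate the two.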